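Phenyl for benzyl on the amide nitrogen of a thiadiazole series

The source may hold more compounds than are shown below. What is called first, only, known or untested is meant among the compounds shown, and "the series" means these compounds.

Three compounds share one core and were tested in an ADME assay on HepG2 cells (Homo sapiens) for cytotoxicity, with a stated time of 3 days; on this read-out higher numbers stand for lower toxicity in this test and lower numbers for higher toxicity in this test. Compound 3 `O=C(CCSc1nnc(-c2ccncc2)s1)NCc1ccccc1` gives 14000 nM in this assay. Compound 1 `O=C(CCSc1nnc(-c2ccncc2)s1)Nc1ccccc1` reports only a limit of the assay, > 50000 nM. Compound 2 `CC(CSc1nnc(-c2ccncc2)s1)C(=O)NCc1ccccc1` likewise reports only a limit, > 50000 nM. The change phenyl in place of benzyl on an amide-type nitrogen gives an at least 3.5-fold higher number from compound 3 to compound 1 (0.55 log units; beyond the scatter), while the core change methyl in place of hydrogen on a saturated chain carbon bound to a carbonyl carbon and a saturated chain carbon gives an at least 3.5-fold lower number from compound 2 to compound 3 (0.55 log units; beyond the scatter). Compound 4 `CC(CSc1nnc(-c2ccncc2)s1)C(=O)Nc1ccccc1` carries the same change as phenyl in place of benzyl on an amide-type nitrogen, from the core of compound 2. Compound 4 is expected to show a step that the limit leaves unreadable from compound 2 to compound 4, which rests on compound 2 already sitting at the limit of > 50000 nM in this assay, at which 2 of the 3 values shown sit, and on the earlier step of an at least 3.5-fold higher number from compound 3 to compound 1 (0.55 log units; beyond the scatter) pointing the same way. Compound 4 is therefore estimated at 90000 nM, most likely reported again as a limit, between 30000 nM and 300000 nM.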

Compound 4, half-maximal cytotoxic concentration: > 50000 nM
Compound 4 ended at the assay's limit; the forecaster's own chance of this, stated with the estimate: 85%; the middle value is on the limit's open side.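

Compound 4 gives only a limit in this assay, > 50000 nM, so its steps from compound 2 and compound 1, both also limits, cannot be read: the limit of > 50000 nM in this assay, at which 3 of the 4 values shown sit.

The compounds shown leave open whether phenyl in place of benzyl changes the read-out at all when the chain carries the methyl.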